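Benzofuran swap on a compound stuck at the limit

The compounds below may be only part of what the source reports. "The series", "measured", "known", "first", "only" and "open" are said of these compounds alone.

Measured so far in a functional assay on HepG2 cells (Homo sapiens) for antiproliferative activity, read by XTT assay, with a stated time of 72 h; on this read-out lower numbers stand for stronger inhibition and higher numbers for weaker inhibition:
- compound 1 `CNc1ncnc2c1c(-c1cc3ccccc3o1)cn2[C@@H]1O[C@H](CO)[C@@H](O)[C@H]1O` gives > 20000 nM (a limit)
- compound 2 `CN(C)c1ncnc2c1c(-c1ccoc1)cn2[C@@H]1O[C@H](CO)[C@@H](O)[C@H]1O` gives 12500 nM
- compound 3 `CN(C)c1ncnc2c1c(-c1ccsc1)cn2[C@@H]1O[C@H](CO)[C@@H](O)[C@H]1O` gives > 20000 nM (a limit)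

Compound 3 has no number, only a limit, and stands at the limit of > 20000 nM in this assay, at which 2 of the 3 values shown sit, in this small set. The change to compound 4 `CN(C)c1ncnc2c1c(-c1cc3ccccc3o1)cn2[C@@H]1O[C@H](CO)[C@@H](O)[C@H]1O` is 1-benzofuran-2-yl in place of thiophen-3-yl on an aromatic carbon on an aromatic carbon of the shared core. Within the data shown here, the one measured step that bears on it is an at least 1.6-fold higher number from compound 2 to compound 3 (0.20 log units; that floor lies within the scatter) and that step exchanges one five-membered group for another. Compound 1 also carries 1-benzofuran-2-yl and is a limit too, at > 20000 nM in this assay without a number. No step beyond the scatter is therefore expected. The expected step is a number no higher from compound 3 to compound 4 (the limit leaves the size open) in size. Compound 4 is estimated at 20000 nM with an expected range from 8000 nM to 50000 nM and may well report only a limit.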

Compound 4, half-maximal inhibitory concentration: > 20000 nM
Compound 4: a limit, no number; the forecaster's own chance of this, stated with the estimate: 65%; the middle value lies on the limit itself.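

In this assay compound 4 gives > 20000 nM, a limit and not a number. The exchange of furan-3-yl for 1-benzofuran-2-yl reads as an at least 1.6-fold higher number from compound 2 to compound 4 (0.20 log units; that floor lies within the scatter), so the added six-membered aromatic ring brings no sign of stronger inhibition, and the steps from compound 3 and from compound 1 cannot be read. The series now gathers at one ceiling: the limit of > 20000 nM in this assay, at which 3 of the 4 values shown sit.

On these data alone, how far apart the compounds at the limit lie remains open. Also open, as far as these compounds go, is whether an amine or a carboxylic acid on this aromatic carbon would give a measurable number.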